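Working notes: aryl exchange on the shared core

The compounds below may be only part of what the source reports. "The series", "measured", "known", "first", "only" and "open" are said of these compounds alone.

Measured so far in a functional assay on MCF7 cells (Homo sapiens) for inhibition, read by sulforhodamine B assay, with a stated time of 72 h; on this read-out higher numbers stand for weaker inhibition and lower numbers for stronger inhibition:
- compound 1, `CC(c1ccc(-c2ccccc2)c(F)c1)c1nnc2n1N=C(c1ccc(Cl)cc1Cl)CS2`; compound 1 gives 7600 nM
- compound 2, `COc1ccc2cc(C(C)c3nnc4n3N=C(c3ccc(Cl)cc3Cl)CS4)ccc2c1`; compound 2 gives 14600 nM
- compound 3, `COc1ccc2cc(C(C)c3nnc4n3N=C(c3ccc(F)cc3)CS4)ccc2c1`; compound 3 gives 15800 nM

Compound 1 has the lowest of the three numbers in this assay. Its gap to compound 2 is within the usual scatter of repeated measurements, so the two cannot be told apart on this read-out; its gap to compound 3 lies beyond the scatter. No ordering stronger than that is supported.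

Compound 4, `CC(c1ccc(-c2ccccc2)c(F)c1)c1nnc2n1N=C(c1ccc(F)cc1)CS2`, has not yet been measured. It differs from compound 1 in one place: 4-fluorophenyl in place of 2,4-dichlorophenyl on a carbon with a double bond to nitrogen. Going by the values given here, the only measured step that bears on this change is the same exchange carried out on a different core, a 1.1-fold higher number from compound 2 to compound 3 (0.03 log units; within the scatter), which stayed within the scatter. Among the compounds with values here, no other step among the measured compounds touches this position.

On that single precedent, the expectation for this assay is a step of about a 1.1-fold higher number from compound 1 to compound 4 (0.05 log units; within the scatter), that is, none beyond the scatter. Compound 4 is therefore estimated at 8500 nM, with a range from 4000 nM to 18000 nM. A single precedent is a thin basis, and the range is set accordingly wide.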

Compound 4, half-maximal inhibitory concentration: 8100 nM
Compound 4: middle estimate off by 1.0-fold (0.02 log units), on the high side; measured number inside the range.
By their numbers in this assay, from the lowest: compounds 1, 4, 2 and 3 (each within the scatter of the next, the first and the last beyond it).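

In this assay, the exchange of 2,4-dichlorophenyl for 4-fluorophenyl on the carbon with a double bond to nitrogen now has a second reading, on a second core, with a 1.1-fold higher number from compound 1 to compound 4 (0.03 log units; within the scatter). The earlier compounds gave this exchange on one core only; it now reads alike on both cores shown, so the lack of a step beyond the scatter is not confined to a single core in this small set: the same change on two cores in this assay, a 1.1-fold higher number (0.03 log units; within the scatter) from compound 2 to compound 3 and a 1.1-fold higher number (0.03 log units; within the scatter) from compound 1 to compound 4, 1.0-fold (0.01 log units) apart, within the scatter of two such steps Both groups are six-membered aromatic rings of carbon only, carrying chlorine or fluorine, so these readings cover an exchange between such phenyl groups and nothing wider.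

The compounds shown leave open whether this position stays as undemanding when it carries something other than a halogen-bearing phenyl group, such as a phenyl group bearing an amine or a carboxylic acid, or a plain butyl chain in place of the aromatic ring. On these data alone, whether the same exchange also stays within the scatter in any read-out other than this assay remains open too.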